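Second methoxy on the styryl lactone series

This account rests on a few compounds, and the source may have more. Where it says the series, first, only, none or still open, it means among the compounds named here.

Compounds measured so far:
compound 1 `COc1ccc(-c2cc(=O)cco2)cc1` > 1230 uM
compound 2 `O=C1C=CCC(/C=C/c2ccc(C(F)(F)F)cc2)O1` 477 uM
compound 3 `COc1ccc(/C=C/C2CC=CC(=O)O2)cc1` 28.3 uM

In a functional assay on NCI-H460 cells (Homo sapiens) for inhibition, read by sulforhodamine B assay, with a stated time of 48 h (a higher number here means a weaker inhibitor of growth, a lower number a stronger inhibitor of growth), compound 1 gives only a limit of the assay, > 1230 uM, not a number (the limit of > 1230 uM in this assay, at which 1 of the 3 values shown sits). Compound 2 gives 477 uM in this assay. Compound 3 gives 28.3 uM, the lowest of the two numbers shown, and the step of a 17-fold lower number from compound 2 to compound 3 (1.23 log units; beyond the scatter) is the only measured one in the series.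

Compound 4 `COc1ccc(/C=C/C2CC=CC(=O)O2)c(OC)c1` differs from compound 3 by methoxy in place of hydrogen on an aromatic carbon. Among the compounds with values here, no measured step exchanges hydrogen for methoxy, so the one step known, from trifluoromethyl to methoxy, does not bear directly on this change; it only shows that a methoxy-bearing aromatic ring sits at the low end of the numbers seen. Within the data shown here, with no direct precedent, the expectation in this assay is a step not beyond the scatter, a 1.1-fold lower number from compound 3 to compound 4 (0.05 log units; within the scatter). Compound 4 is therefore estimated at 25 uM, within a range of 8 uM to 80 uM.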

Compound 4, concentration for growth inhibition (reported as GI): 6 uM
For compound 4 the middle estimate is 4.2-fold (0.62 log units) above the measured one, and the stated range ends above it.
By their numbers in this assay, from the lowest: compound 4; then compound 3; then compound 2. At a limit, above all of these: compound 1.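

In this assay, methoxy in place of hydrogen on an aromatic carbon, ortho to a group of 9 heavy atoms and meta to a methoxy group, gives a 4.7-fold lower number from compound 3 to compound 4 (0.67 log units; beyond the scatter). This is the first step in the series that adds a group to the ring instead of exchanging one, and it shows that this position accepts a second methoxy with a lower number beyond the scatter, leaving compound 4 with the lowest number shown. Nothing shown accounts for the size of this step.

Still open, from the compounds shown here alone, is whether the step is particular to methoxy or would also follow from a hydroxyl, an amine or a longer chain such as ethoxy on the same carbon. Also open, going by these compounds, is whether methoxy at this carbon would give a similar step without the existing methoxy group.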